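This account rests on a few compounds, and the source may have more. Where it says the series, first, only, none or still open, it means among the compounds named here.

Measured so far in a functional assay on the whole organism (artery, strain albino) with Rattus norvegicus as the target, with a stated time of 15 min, at a dose of 10 mg/kg by the oral route; a higher number here means more inhibition at the dose given (going by the name of the read-out), a lower number less inhibition:
compound 1 `CC1=C(C(=O)Nc2ccc(F)cc2)C(c2ccc([N+](=O)[O-])cc2)N=C(SCc2ccccc2)N1` gives 3.1%;
compound 2 `CC1=C(C(=O)Nc2ccc(F)cc2)C(c2ccc([N+](=O)[O-])cc2)N=C(SCc2cccc(Cl)c2)N1` gives 2.1%;
compound 3 `COc1ccc(C2N=C(SCc3ccccc3)NC(C)=C2C(=O)Nc2ccc(Br)cc2)cc1` gives 1%.

All three numbers sit close together. Among the compounds with values here, the one change seen twice over is chloro in place of hydrogen on an aromatic carbon, which made the step of a number 1 percentage points lower from compound 1 to compound 2 (within the scatter). Compound 3 and compound 1 share a related scaffold, but the difference between the two cores is not broken down here; what compound 3 shows is that its reading lies within the scatter of both compound 1 and compound 2.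

Compound 4 `COc1ccc(C2N=C(SCc3ccccc3Cl)NC(C)=C2C(=O)Nc2ccc(Br)cc2)cc1` is not yet measured. It is made from compound 3 by chloro in place of hydrogen on an aromatic carbon. This is the same kind of change as that from compound 1 to compound 2, not the same: there the chloro is meta to a large group, here ortho to a large group. Because a number 1 percentage points lower from compound 1 to compound 2 (within the scatter) lay within the scatter, only a small step is expected, a number 0.5 percentage points higher from compound 3 to compound 4 (within the scatter). Compound 4 is therefore estimated at 1.5%, between -5% and 8%.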

Compound 4, a percentage reported as inhibition, in the whole organism at one dose (the size of the read-out at that dose, not a potency): 3.1%
Compound 4: the middle estimate sits 1.6 percentage points below what was measured; low and high end bracket the measured number.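

In this assay, chloro in place of hydrogen on an aromatic carbon gave a number 2.1 percentage points higher from compound 3 to compound 4 (within the scatter). Set beside the earlier step, the two cores do not part for this change: the same change on two cores in this assay, a number 1 percentage points lower (within the scatter) from compound 1 to compound 2 and a number 2.1 percentage points higher (within the scatter) from compound 3 to compound 4, 3.1 percentage points apart, within the scatter of two such steps. This shows that on neither core did the change move the reading beyond the scatter, but it does not show that the chloro has any effect of its own, or that a step would carry over where a larger one occurs, and the chloro of compound 4 sits ortho to a large group, unlike that of compound 2.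

The compounds shown leave open whether a different group on the benzyl ring, such as an amine or a carboxylic acid, would move the reading beyond the scatter.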